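The source may hold more compounds than are shown below. What is called first, only, known or untested is meant among the compounds shown, and "the series" means these compounds.

Measured so far in an ADME assay on MDBK cells (Bos taurus) for cytotoxicity, read by MTT assay, with a stated time of 96 h; a higher number here means that more compound is tolerated, a lower number that less compound is tolerated:
compound 1 `COc1ccc(-c2nc3cc(C(C)=O)ccc3[nH]2)c(OC)c1`: 73000 nM
compound 2 `COc1ccc(-c2nc3cc(C(C)O)ccc3[nH]2)c(OC)c1`: > 100000 nM (a limit)
compound 3 `COc1ccc(-c2nc3cc(/C(C)=N/NC(N)=O)ccc3[nH]2)c(OC)c1`: > 100000 nM (a limit)

Among the compounds with values here, compound 1 holds the only true number of the three, and the other two stand at the limit of > 100000 nM in this assay, at which 2 of the 3 values shown sit. The next compound is compound 4 `COc1ccc(-c2nc3cc(C(C)=O)ccc3n2C2CCCCC2)c(OC)c1`, with the change (cyclohexyl in place of hydrogen on an aromatic nitrogen).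

Two measured steps start from compound 1: an at least 1.3-fold higher number from compound 1 to compound 2 (0.13 log units; that floor lies within the scatter) and an at least 1.3-fold higher number from compound 1 to compound 3 (0.13 log units; that floor lies within the scatter). Both replace the acetyl group on an aromatic carbon, so they bear only loosely on a change at the aromatic nitrogen. The step that the two limits leave unreadable from compound 2 to compound 3 adds nothing further. Within the data shown here, no measured step changes that nitrogen, so the data give no direct guide to size or direction.

The expectation in this assay is therefore no step beyond the scatter, with a slight lean towards a lower number and a wide range. The estimated step is a 1.5-fold lower number from compound 1 to compound 4 (0.16 log units; within the scatter). For compound 4 the expected value is 50000 nM, with an estimated range of 15000 nM to 100000 nM.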

Compound 4, half-maximal cytotoxic concentration: 21000 nM
Beside the measured number, compound 4's estimate is 2.4-fold (0.38 log units) above it; the range from low to high includes it.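

In this assay, within the data shown here, placing cyclohexyl on the aromatic nitrogen gives a 3.5-fold lower number from compound 1 to compound 4 (0.54 log units; beyond the scatter), so this position, unchanged in the earlier compounds, does affect how much compound is tolerated. Among these compounds, this is the only step printed as beyond the scatter, and it runs towards less compound tolerated, whereas the two changes at the acetyl group offer only floors that lie within the scatter. Nothing shown here accounts for the size or direction of this step.

On these data alone, it remains open whether a methyl group, a benzyl group or a longer chain ending in an amine on the same nitrogen would move the number in the same way. Also open, as far as these compounds go, is whether cyclohexyl would have a similar effect with 1-hydroxyethyl in place of acetyl.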